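Adding a Methyl Where No Inhibition Has Yet Appeared

The source may report more compounds than this note shows. Statements on the series, on what has been measured and on what is new or still open speak of the compounds shown alone.

Of the compounds shown here, two built on a shared core have been tested for their power to slow the growth of lung cancer cells. In a functional assay on A549 cells (Homo sapiens) for antiproliferative activity, read by XTT assay, with a stated time of 24 h (on this read-out lower numbers stand for stronger inhibition and higher numbers for weaker inhibition), compound 1 `Cc1ccc(-c2csc(N3N=C(c4ccc(C)s4)CC3c3ccc(F)cc3)n2)cc1` gives no number but only a limit of > 500 ug/mL. In this assay compound 2 `Fc1ccc(C2CC(c3ccc(Cl)s3)=NN2c2nc(-c3ccccc3)cs2)cc1` likewise reaches only a limit of > 500 ug/mL. Compound 2 therefore cannot be placed above or below compound 1; both values sit at the same boundary, as the limit of > 500 ug/mL in this assay, at which 2 of the 2 values shown sit, shows.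

Compound 3 `Cc1ccc(-c2csc(N3N=C(c4ccc(Cl)s4)CC3c3ccc(F)cc3)n2)cc1` differs from compound 2 by methyl in place of hydrogen on an aromatic carbon. Among the compounds with values here, no step between two measured numbers exists here, so nothing shows how such a change shifts the read-out. Compound 1 already carries the 4-methylphenyl group and still sits at the limit. The expected step from compound 2 to compound 3 in this assay is therefore a step that the limit leaves unreadable from compound 2 to compound 3, none beyond the scatter. Compound 3 is estimated at 600 ug/mL, with a range from 200 ug/mL to 2000 ug/mL, and most likely the assay will again report only a limit.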

Compound 3, half-maximal inhibitory concentration: > 500 ug/mL
Compound 3 gave a limit, no number (the forecaster's own chance of this, stated with the estimate: 85%); the middle value is on the limit's open side.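

Within the data shown here, compound 3 also gives only a limit in this assay, so no step from compound 2 or compound 1 to compound 3 can be read: the limit of > 500 ug/mL in this assay, at which 3 of the 3 values shown sit. The compounds shown leave open whether methyl in place of hydrogen, or chloro in place of methyl, shifts the read-out at all, and what change to the shared core would yield a measured number.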